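A few compounds are considered here, and "the series" means these few. Any claim that something is new, unique, unknown or untested is made for them only; others in the source may bear on it.

Measured compounds in an assay on CHO cells for displacement of a labelled ligand from 5-hydroxytryptamine receptor 7 (Homo sapiens); on this read-out lower numbers stand for stronger inhibition and higher numbers for weaker inhibition:
- compound 1, `O=S(=O)(NCCCN1CCN(c2ccc(C(F)(F)F)cc2)CC1)c1ccc2ccccc2c1`, 567 nM
- compound 2, `O=S(=O)(NCCCN1CCN(c2ccccc2)CC1)c1ccc2ccccc2c1`, 681 nM
- compound 3, `COc1ccc(S(=O)(=O)NC(C)CCN2CCN(c3cccc(C(F)(F)F)c3)CC2)cc1`, 107 nM

Compound 1 and compound 2 share one core; compound 3 has another, and the difference between the two cores is not broken down here. Compound 3 gives the lowest number of the three in this assay, and its gaps to compound 1 and to compound 2 both lie beyond the scatter.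

Among the measured compounds shown here, the one step measured within a single core is a 1.2-fold higher number from compound 1 to compound 2 (0.08 log units; within the scatter). The change behind it is hydrogen in place of trifluoromethyl on an aromatic carbon.

Compound 4, `COc1ccc(S(=O)(=O)NC(C)CCN2CCN(c3ccccc3)CC2)cc1`, is not yet measured. It differs from compound 3 by hydrogen in place of trifluoromethyl on an aromatic carbon. For the measured compounds named here, this is the same kind of change as the one from compound 1 to compound 2, though not the same: in compound 1 the trifluoromethyl sits para to a large group, in compound 3 meta to a large group, and the surrounding core is different.

Going by the values given here, the only guide is the measured step, which stayed within the scatter. On that basis, the step from compound 3 to compound 4 is expected to be about a 1.3-fold higher number from compound 3 to compound 4 (0.12 log units; within the scatter) in this assay, with some extra width allowed for the different place and core. Compound 4 is therefore estimated at 140 nM, with a range from 70 nM to 300 nM.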

Compound 4, half-maximal inhibitory concentration: 377 nM
Beside the measured number, compound 4's estimate is 2.7-fold (0.43 log units) below it; measured number outside the range, above it.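

In this assay the change from 3-(trifluoromethyl)phenyl to phenyl gives a 3.5-fold higher number from compound 3 to compound 4 (0.55 log units; beyond the scatter), so on the core of compound 3 the number depends on this group to a degree beyond the scatter. Set beside the earlier step, the same change does not carry over at the same size from one core to another in this series: the same change on two cores in this assay, a 1.2-fold higher number (0.08 log units; within the scatter) from compound 1 to compound 2 and a 3.5-fold higher number (0.55 log units; beyond the scatter) from compound 3 to compound 4, 2.9-fold (0.47 log units) apart, beyond the scatter of two such steps This does not show whether the core or the place of the trifluoromethyl sets the size of the step, as the two pairs differ in both, and two pairs give no general rule for other cores.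

Still open, from the compounds shown here alone, is what a 3-(trifluoromethyl)phenyl would give on the core of compound 1, a comparison that would hold the place fixed and vary only the core, and what the trifluoromethyl would give at the place it holds in compound 1 on the core of compound 3. Also open, going by these compounds, is whether other groups at the place held by the trifluoromethyl in compound 3, such as chlorine, a nitrile or a methyl, would give numbers closer to compound 3 or to compound 4.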